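The source may hold more compounds than are shown below. What is called first, only, known or untested is meant among the compounds shown, and "the series" means these compounds.

Compound 3 `COC(=O)C[C@H](NC(=O)OC(C)(C)C)C(=O)N(Cc1ccc(F)cc1)C1(C(=O)NCc2ccccc2)CCN(C)CC1` is the reference for this step. In an ADME assay on MDCK cells (Canis lupus familiaris) for cytotoxicity, read by microscopy, with a stated time of 72 h (a higher number here means that more compound is tolerated, a lower number that less compound is tolerated), compound 3 gives 17000 nM. Compound 2 `COC(=O)C[C@H](NC(=O)OC(C)(C)C)C(=O)N(Cc1ccc(F)cc1)C(C)(C)C(=O)NCc1ccccc1` gives 20000 nM in this assay; on the numbers shown compound 3 stands together with compound 2, the two within the usual scatter of each other, so nothing separates them. Compound 1 `COC(=O)C[C@H](NC(=O)OC(C)(C)C)C(=O)N(Cc1ccccc1)C1(C(=O)NCc2ccccc2)CCN(Cc2ccccc2)CC1` reaches only a limit of this assay, > 100000 nM, which is a limit and not a number (the limit of > 100000 nM in this assay, at which 1 of the 3 values shown sits). Compound 4 `COC(=O)C[C@H](NC(=O)OC(C)(C)C)C(=O)N(Cc1ccc(F)cc1)C1(C(=O)NCc2ccccc2)CCN(c2ccccc2)CC1` carries a single change against compound 3: phenyl in place of methyl on an amine nitrogen in a ring. Going by the values given here, no measured step of this kind is known, so the shift is an expectation only: a modest move toward a lower tolerated concentration, a 1.7-fold lower number from compound 3 to compound 4 (0.23 log units; within the scatter). Compound 4 is expected to give 10000 nM in this assay, within 3000 nM to 40000 nM.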

Compound 4, minimum cytotoxic concentration: 20000 nM
For compound 4 the middle estimate is 2.0-fold (0.30 log units) below the measured one; measured number inside the range.
By their numbers in this assay, from the lowest: compounds 3, 2 and 4 (each within the scatter of the next). At a limit, above all of these: compound 1.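

In this assay, going by these compounds alone, the one step read at this position is a 1.2-fold higher number from compound 3 to compound 4 (0.07 log units; within the scatter). On an amine nitrogen in a ring, phenyl in place of methyl therefore gives no separable change, even though the entering group brings a six-membered aromatic ring of carbon only.

Still open, on these data alone, is whether an acetyl group, a carboxylic acid or a longer chain on this nitrogen would also stay within the scatter of compound 3. No measurement shown bears on the reason for the result with phenyl.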